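The compounds below may be only part of what the source reports. "The series", "measured", "known", "first", "only" and "open" are said of these compounds alone.

In a functional assay on HeLa cells (Homo sapiens) for inhibition (a higher number here means a weaker inhibitor, a lower number a stronger inhibitor), compound 1, `CC(C)C(NC(=O)NO)C(=O)NC1CCCCC1`, gives only a limit of the assay, > 100000 nM. Compound 2, `CCC(C)C(NC(=O)NO)C(=O)NC1CCCCC1`, likewise gives only a limit, > 100000 nM. Compound 2 carries methyl in place of hydrogen on a saturated chain carbon, three bonds along the chain from an amide-type nitrogen and a carbonyl carbon, and the two limits leave a step that the two limits leave unreadable from compound 1 to compound 2. Compound 3, `CC(C)C(NC(=O)n1nnc2ccccc21)C(=O)NC1CCCC1`, rests on a different core; the difference between the two cores is not broken down here. In this assay compound 3 gives 96400 nM. Compound 4, `CCC(C)C(NC(=O)n1nnc2ccccc21)C(=O)NC1CCCC1`, has not yet been measured; it carries methyl in place of hydrogen on a saturated chain carbon, three bonds along the chain from an amide-type nitrogen and a carbonyl carbon, the same change as from compound 1 to compound 2. With the earlier step unreadable, the expectation rests on compound 3 sitting close to the limit of > 100000 nM in this assay, at which 2 of the 3 values shown sit, so a 1.2-fold higher number from compound 3 to compound 4 (0.10 log units; within the scatter) is expected to be small and a further limit is quite possible. Compound 4 is therefore estimated at 120000 nM, between 50000 nM and 300000 nM.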

Compound 4, half-maximal inhibitory concentration: 82300 nM
The estimate for compound 4 lay 1.5-fold (0.16 log units) above the measured number; measured number inside the range.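

In this assay, methyl in place of hydrogen gives a 1.2-fold lower number from compound 3 to compound 4 (0.07 log units; within the scatter), so on the core of compound 3 the change has no effect that can be told apart from the scatter. On the core of compound 1, both values are limits of the assay and the step from compound 1 to compound 2 cannot be read, so nothing shows whether the change behaves alike on the two cores. Any reading of this transfer stays narrow because so few values here are true numbers: the limit of > 100000 nM in this assay, at which 2 of the 4 values shown sit.

Left open is what a longer chain or an amine in place of the methyl would do to the number in this assay. Also open, on these data alone, is whether the methyl step would stay this small on a core whose values lie well clear of the limit.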